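A few compounds are considered here, and "the series" means these few. Any claim that something is new, unique, unknown or untested is made for them only; others in the source may bear on it.

Working notes on the series. Among the measured compounds shown here, in a functional assay on PA-1 cells (Homo sapiens) for cytotoxicity, read by MTT assay, with a stated time of 4 h (on this read-out higher numbers stand for weaker inhibition and lower numbers for stronger inhibition), compound 1 `CCC(=O)OC[C@H]1O[C@@H](O[C@@H]2OC=C(C(=O)OC)[C@H]3C[C@H](OC(C)=O)[C@H](C)[C@@H]23)[C@H](OC(C)=O)[C@@H](OC(C)=O)[C@@H]1OC(C)=O` gives 1.24 ug/mL and compound 2 `CCCCCCCCCCCC(=O)OC[C@H]1O[C@@H](O[C@@H]2OC=C(C(=O)OC)[C@H]3C[C@H](OC(C)=O)[C@H](C)[C@@H]23)[C@H](OC(C)=O)[C@@H](OC(C)=O)[C@@H]1OC(C)=O` gives 0.15 ug/mL, so compound 2 holds the lower of the two numbers measured so far. The next structure, compound 3 `COC(=O)C1=CO[C@@H](O[C@@H]2O[C@H](COC(=O)C=C(C)C)[C@@H](OC(C)=O)[C@H](OC(C)=O)[C@H]2OC(C)=O)[C@@H]2[C@@H](C)[C@@H](OC(C)=O)C[C@H]12`, differs from compound 2 as follows: 2-methylprop-1-en-1-yl in place of undecyl on a carbonyl carbon. In words, this is 2-methylprop-1-en-1-yl in place of undecyl on a carbonyl carbon. For the measured compounds named here, one measured step bears on this change: an 8.3-fold lower number from compound 1 to compound 2 (0.92 log units; beyond the scatter), with nonyl in place of hydrogen on the chain. Compound 3 gives up most of that added chain, so a move towards higher numbers in this assay is expected, beyond the scatter. Going by the values given here, no measured compound carries the entering group, which leaves the size uncertain. The expected step is a 4.7-fold higher number from compound 2 to compound 3 (0.67 log units; beyond the scatter). The estimated value for compound 3 is 0.7 ug/mL, with an expected range of 0.25 ug/mL to 1.8 ug/mL.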

Compound 3, half-maximal inhibitory concentration: 0.65 ug/mL
The estimate for compound 3 lay 1.1-fold (0.03 log units) above the measured number; measured number inside the range.
By their numbers in this assay, from the lowest: compound 2; then compounds 3 and 1 (each within the scatter of the next).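

On this carbonyl carbon, the shorter 2-methylprop-1-en-1-yl group does not retain the low number seen with undecyl in this assay: there is a 4.3-fold higher number from compound 2 to compound 3 (0.64 log units; beyond the scatter). Against the ethyl group the same entering group gives a 1.9-fold lower number from compound 1 to compound 3 (0.28 log units; within the scatter), so the double bond and the added carbons of 2-methylprop-1-en-1-yl bring no change that can be told from the scatter, and among these three compounds only the undecyl chain stands apart. No supporting data bear on why the undecyl chain gives the lowest number.

The compounds shown leave open whether the number falls steadily with chain length or only beyond some length, a question that heptyl and pentadecyl chains on this carbonyl carbon would address. A saturated 2-methylpropyl group would separate the contribution of the double bond from that of the branching.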